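Trimethylsilylethynyl in place of cyano on the amino-bearing ring

The compounds below may be only part of what the source reports. "The series", "measured", "known", "first", "only" and "open" are said of these compounds alone.

Working notes on the series. Compound 1 `C[Si](C)(C)C#Cc1cc(-c2nc3ccc(F)cc3s2)ccc1N` and compound 2 `N#Cc1cc(-c2nc3ccccc3s2)ccc1N` share the same core with an amino group on the outer ring. In a functional assay on MCF7 cells (Homo sapiens) for inhibition, with a stated time of 72 h (a higher number here means a weaker inhibitor of growth, a lower number a stronger inhibitor of growth), compound 1 gives 680 nM. In this assay compound 2 gives 580 nM. Where compound 2 stands: its number lies within the scatter of that of compound 1, so the two measured compounds are not separated by the data, and no step between measured compounds that differ in one place is available.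

Compound 3 `C[Si](C)(C)C#Cc1cc(-c2nc3ccccc3s2)ccc1N` is the unmeasured member. Relative to compound 2 the change is a group of 6 heavy atoms (5 carbon, 1 silicon; no ring) in place of a group of 2 heavy atoms (1 carbon, 1 nitrogen; no ring), on an aromatic carbon, in words a group of 6 heavy atoms (5 carbon, 1 silicon; no ring) in place of a group of 2 heavy atoms (1 carbon, 1 nitrogen; no ring), on an aromatic carbon. Within the data shown here, the entering group is the one carried by compound 1, which in this assay gives 680 nM. With compound 1 and compound 2 within the scatter of each other, the step from compound 2 to compound 3 is expected to be a 1.1-fold higher number from compound 2 to compound 3 (0.05 log units; within the scatter), no direction beyond the scatter. Compound 3 is therefore estimated at 650 nM, range 300 nM to 1400 nM.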

Compound 3, concentration for 50% growth inhibition: 710 nM
Compound 3: middle estimate off by 1.1-fold (0.04 log units), on the low side, within the range that was stated.
By their numbers in this assay, from the lowest: compounds 2, 1 and 3 (each within the scatter of the next).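

At the aromatic carbon ortho to an amino group, the group of 6 heavy atoms (5 carbon, 1 silicon; no ring) in place of cyano can now be read as a direct step in this assay (a 1.2-fold higher number from compound 2 to compound 3 (0.09 log units; within the scatter)), and this step does not separate the two groups. Hydrogen in place of fluoro on an aromatic carbon can also be read directly (a 1.0-fold higher number from compound 1 to compound 3 (0.02 log units; within the scatter)), and it does not separate its pair either. Compound 1 and compound 2 differ in two places, so compound 3 splits that earlier comparison into two single changes, and in this assay neither change exceeds the scatter; no supporting data on hand bear on the reason for this result.

Still open, on these data alone, is whether any group at this carbon gives a step beyond the scatter, as an amine, a carboxylic acid or a longer alkyl chain in place of cyano might. Among these compounds, also open is whether chloro or methoxy in place of fluoro on the shared core reads the same way in this assay and whether fluoro combined with cyano matches the single changes seen here.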